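The source may hold more compounds than are shown below. What is called first, only, known or untested is meant among the compounds shown, and "the series" means these compounds.

Measured so far in an ADME assay on MT4 cells (Homo sapiens) for cytotoxicity, read by MTT assay, with a stated time of 5 days; on this read-out lower numbers stand for higher toxicity in this test and higher numbers for lower toxicity in this test:

compound 1 `O=C(CSc1ncnn1-c1ccc(Cl)cc1Cl)Nc1ccc(Cl)cc1Cl`: 172000 nM
compound 2 `O=C(CSc1ncnn1-c1ccc(Cl)cc1Cl)Nc1ccccc1[N+](=O)[O-]`: 187000 nM
compound 3 `CC(=O)c1ccc(NC(=O)CSc2ncnn2-c2ccc(Cl)cc2Cl)c(Br)c1`: 114000 nM

In this assay compound 3 gives 114000 nM and stands within the scatter of both compound 1 and compound 2, so the three values cannot be ranked.

The next structure is compound 4 `O=C(CSc1ncnn1-c1ccc(Cl)cc1Cl)Nc1ccc(Cl)cc1Br`, which differs from compound 3 at a single place: chloro in place of acetyl on an aromatic carbon. This is chloro in place of acetyl on an aromatic carbon, meta to a bromo group and para to a large group.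

Within the data shown here, no measured pair shows this exchange directly. Among the measured compounds shown here, the only measured step that bears on it is a 1.1-fold higher number from compound 1 to compound 2 (0.04 log units; within the scatter), a change at a different group on the same side of the amide-type nitrogen, and it stays within the scatter. Across these three compounds, the changes on that aromatic ring have not moved the read-out beyond the scatter, and no measured compound goes against this. With so few compounds, this is weak support.

The expected step is a 1.3-fold higher number from compound 3 to compound 4 (0.12 log units; within the scatter), so no change beyond the scatter is anticipated.

Compound 4 is estimated at 150000 nM with an expected range of 85000 nM to 250000 nM in this assay for now.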

Compound 4, half-maximal cytotoxic concentration: 189000 nM
Compound 4: the middle estimate sits 1.3-fold (0.10 log units) below what was measured; the measured number falls inside the stated range.
By their numbers in this assay, from the lowest: compounds 3, 1, 2 and 4 (each within the scatter of the next).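

In this assay, the acetyl group on this aromatic carbon, para to a large group, can give way to a single chloro with the read-out staying within the scatter: a 1.7-fold higher number from compound 3 to compound 4 (0.22 log units; within the scatter). This exchange removes the carbonyl and its hydrogen-bond acceptor, so at this position, across these two compounds, neither the acceptor nor the larger group shows a change beyond the scatter. The two other new steps, a 1.1-fold higher number from compound 1 to compound 4 (0.04 log units; within the scatter) for bromo in place of chloro on an aromatic carbon and a 1.0-fold higher number from compound 2 to compound 4 (0.00 log units; within the scatter) for 2-bromo-4-chlorophenyl in place of 2-nitrophenyl on an amide-type nitrogen, also stay within the scatter, and no measurement on hand accounts for this lack of separation.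

Among these compounds, all four compounds share the same core and differ only in the substituents on one aromatic ring, so no step yet shows what would move this read-out beyond the scatter. Going by these compounds, it remains open whether an amine, a carboxylic acid or a longer chain at the carbon para to the large group would leave the read-out within the scatter as well.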